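The compounds below may be only part of what the source reports. "The series", "measured", "known", "first", "only" and "open" are said of these compounds alone.

Measured so far:
- compound 1 `C[C@@H](Oc1cc2oc(=O)n(CCC(=O)O)c2cc1Cl)c1ccc(F)cn1`: 25.1 nM
- compound 2 `C[C@@H](Oc1cc2oc(=O)n(CCC(=O)O)c2cc1Cl)c1cccnn1`: 631 nM

Both were tested in an assay on HEK293 cells for inhibition of kynurenine 3-monooxygenase (Homo sapiens), read by LC-MS, with a stated time of 20 h; a higher number here means a weaker inhibitor, a lower number a stronger inhibitor. Compound 2 stands at the highest of the two numbers; its nearest neighbour is compound 1, and the step of a 25-fold higher number from compound 1 to compound 2 (1.40 log units; beyond the scatter) was large. Compound 3 `Cc1cccc([C@@H](C)Oc2cc3oc(=O)n(CCC(=O)O)c3cc2Cl)n1` is not yet measured. It differs from compound 2 as follows: 6-methylpyridin-2-yl in place of pyridazin-3-yl on a saturated chain carbon bound to an oxygen on an aromatic ring and a saturated chain carbon. Among the measured compounds shown here, the only measured step that bears on this is the one from compound 1 to compound 2, where pyridazin-3-yl replaced 5-fluoropyridin-2-yl and the number rose sharply. For the measured compounds named here, compound 3 reverses that kind of change, putting 6-methylpyridin-2-yl in the same place, a group closer to the one in compound 1 than to the one in compound 2. A large step downward, toward the value of compound 1, is therefore expected, a 20-fold lower number from compound 2 to compound 3 (1.29 log units; beyond the scatter). For compound 3 the estimate is 32 nM, within a range of 10 nM to 100 nM.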

Compound 3, half-maximal inhibitory concentration: 316 nM
The estimate for compound 3 lay 9.9-fold (0.99 log units) below the measured number; measured number above the stated range.
By their numbers in this assay, from the lowest: compound 1; then compounds 3 and 2 (each within the scatter of the next).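

In this assay the change from 5-fluoropyridin-2-yl to 6-methylpyridin-2-yl gives a 13-fold higher number from compound 1 to compound 3 (1.10 log units; beyond the scatter) at this position, so a six-membered aromatic ring with one hetero atom does not by itself keep the low number of compound 1. The change from pyridazin-3-yl to 6-methylpyridin-2-yl gives a 2.0-fold lower number from compound 2 to compound 3 (0.30 log units; within the scatter) and so does not separate these two groups, although the ring's hetero atoms differ in number and a methyl group enters. Among the three groups shown, only 5-fluoropyridin-2-yl gives a number clearly apart from the others.

An unsubstituted pyridin-2-yl group would help show whether the fluorine of compound 1 or the methyl of compound 3 accounts for the step between them. Nothing shown here gives a measured reason for these differences.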